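Fluoro for bromo on the aromatic ring: compound 4

The source may report more compounds than this note shows. Statements on the series, on what has been measured and on what is new or still open speak of the compounds shown alone.

Compound 3 `CCOC(=O)c1c(N)sc(/N=C/c2ccc(Br)cc2)c1C(=O)OCC` gives 46100 nM in a functional assay on Ishikawa cells (Homo sapiens) for inhibition, read by MTT assay, with a stated time of 48 h; a lower number here means a stronger inhibitor, a higher number a weaker inhibitor. Among the three measured numbers it stands second highest. Compound 1 `CCOC(=O)c1c(N)sc(/N=C/c2ccccc2)c1C(=O)OCC` gives 37900 nM, and compound 2 `CCOC(=O)c1c(N)sc(/N=C/c2ccco2)c1C(=O)OCC` gives 69300 nM; all three values lie within the scatter of one another: a 1.2-fold higher number from compound 1 to compound 3 (0.09 log units; within the scatter), a 1.8-fold higher number from compound 1 to compound 2 (0.26 log units; within the scatter), a 1.5-fold lower number from compound 2 to compound 3 (0.18 log units; within the scatter). Compound 4 `CCOC(=O)c1c(N)sc(/N=C/c2ccc(F)cc2)c1C(=O)OCC` is not yet measured. It differs from compound 3 in one place: fluoro in place of bromo on an aromatic carbon. The measured step that bears most directly on this change is the earlier one of bromo in place of hydrogen on an aromatic carbon, a 1.2-fold higher number from compound 1 to compound 3 (0.09 log units; within the scatter), which stayed within the scatter. The larger exchange of the whole aromatic ring for furan-2-yl, seen in a 1.8-fold higher number from compound 1 to compound 2 (0.26 log units; within the scatter) and a 1.5-fold lower number from compound 2 to compound 3 (0.18 log units; within the scatter), also moved the number no further than the scatter. Nothing in the series therefore points to a step beyond the scatter for fluoro in place of bromo, in either direction, and the expected step of a 1.1-fold lower number from compound 3 to compound 4 (0.04 log units; within the scatter) is flat. For compound 4 in this assay the estimate is 42000 nM, with a range from 20000 nM to 90000 nM, kept wide since all readings of the series sit at weak inhibition.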

Compound 4, half-maximal inhibitory concentration: 32100 nM
The estimate for compound 4 lay 1.3-fold (0.12 log units) above the measured number, within the range that was stated.
By their numbers in this assay, from the lowest: compounds 4, 1, 3 and 2 (each within the scatter of the next, the first and the last beyond it).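

In this assay, the aromatic carbon para to a large group tolerates fluoro in place of bromo (a 1.4-fold lower number from compound 3 to compound 4 (0.16 log units; within the scatter)) and fluoro in place of hydrogen (a 1.2-fold lower number from compound 1 to compound 4 (0.07 log units; within the scatter)) with both steps within the scatter, so this read-out does not separate hydrogen, bromo and fluoro at this place. Going by these compounds alone, the new information lies in the exchange of the whole ring: 4-fluorophenyl in place of furan-2-yl gives the first step beyond the scatter (a 2.2-fold lower number from compound 2 to compound 4 (0.33 log units; beyond the scatter)), though a modest one, whereas the corresponding steps from furan-2-yl to phenyl and to 4-bromophenyl stayed within it. No measurement at hand bears on the origin of this step.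

On these data alone, whether a methoxy group, an amine or a carboxylic acid on the same aromatic carbon would move the number beyond the scatter remains open. Also open, as far as these compounds go, is whether the shared core responds to other changes, such as a longer chain in place of the ethyl groups of the esters or an amide in place of the free amino group.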